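Notes on the 4-nitrophenoxy to 2-fluorophenoxy change

A few compounds are considered here, and "the series" means these few. Any claim that something is new, unique, unknown or untested is made for them only; others in the source may bear on it.

Compound 1 `CC(C)[C@H](NC(=O)COc1cccc2ccccc12)C(=O)N[C@@H](CC(=O)O)C(=O)COc1ccc2ccccc2c1`: 15900 nM
Compound 2 `CC(C)[C@H](NC(=O)COc1cccc2ccccc12)C(=O)N[C@@H](CC(=O)O)C(=O)COc1ccc([N+](=O)[O-])cc1`: 22800 nM

For the measured compounds named here, in a functional assay with Homo sapiens as the target (on this read-out lower numbers stand for stronger inhibition and higher numbers for weaker inhibition), compound 2 gives 22800 nM, which lies within the scatter of the only other measured member, compound 1, at 15900 nM. Compound 3 `CC(C)[C@H](NC(=O)COc1cccc2ccccc12)C(=O)N[C@@H](CC(=O)O)C(=O)COc1ccccc1F` is the next to be read. It differs from compound 2 as follows: 2-fluorophenyl in place of 4-nitrophenyl on an oxygen on a saturated carbon. The core is unchanged, with 2-fluorophenyl in place of 4-nitrophenyl on an oxygen on a saturated carbon.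

Going by the values given here, one measured step bears on this place: a 1.4-fold higher number from compound 1 to compound 2 (0.16 log units; within the scatter). That exchange of naphthalen-2-yl for 4-nitrophenyl left the number within the scatter. Among the compounds with values here, no measured compound carries 2-fluorophenyl, so the evidence is thin, and no step beyond the scatter is expected in this assay. The expected change is a 1.1-fold lower number from compound 2 to compound 3 (0.06 log units; within the scatter). For compound 3 the estimated value is 20000 nM, with an expected range of 8000 nM to 50000 nM.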

Compound 3, half-maximal inhibitory concentration: 15700 nM
Beside the measured number, compound 3's estimate is 1.3-fold (0.11 log units) above it; the measured number falls inside the stated range.
By their numbers in this assay, from the lowest: compounds 3, 1 and 2 (each within the scatter of the next).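

In this assay, exchanging 4-nitrophenyl for 2-fluorophenyl gives a 1.5-fold lower number from compound 2 to compound 3 (0.16 log units; within the scatter), and exchanging naphthalen-2-yl for 2-fluorophenyl gives a 1.0-fold lower number from compound 1 to compound 3 (0.01 log units; within the scatter). All three groups on this oxygen on a saturated carbon therefore read within the scatter of one another, and this now includes a group with 0 hydrogen-bond acceptors alongside 4-nitrophenyl with 2, and a group of 7 heavy atoms alongside one of 9. Nothing measured here offers an explanation for this flat reading.

The compounds shown leave open whether any group at this place can move the number beyond the scatter. A longer saturated chain without an aromatic ring, or a phenyl ring carrying an amine, would test whether an aromatic group of this kind matters here at all.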